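The compounds below may be only part of what the source reports. "The series", "measured", "known", "first", "only" and "open" are said of these compounds alone.

Compound 1 `Cc1ccc2c(c1)N(C1=CCCC1=O)CC(C)(C)S2` stands second highest of three in a functional assay on aorta (Rattus norvegicus, strain Wistar) (a lower number here means a smaller maximal response, a higher number a larger maximal response), where compound 1 gives 89%. Its nearest neighbour is compound 2 `CC(=O)c1ccc2c(c1)N(C1=CCCC1=O)CC(C)(C)S2`, which in this assay gives 88%; the furthest is compound 3 `CC1CN(C2=CCCC2=O)c2cc(C(F)(F)F)ccc2S1`, which gives 94%, and both sit within the scatter of compound 1. Compound 4 `CCc1ccc2c(c1)N(C1=CCCC1=O)CC(C)(C)S2` differs from compound 1 by methyl in place of hydrogen on a saturated chain carbon bound to an aromatic carbon. Going by the values given here, the only measured step that bears on this, a number 1 percentage points lower from compound 1 to compound 2 (within the scatter), stayed within the scatter, and all three numbers lie close together, so the shared core appears to carry the maximal response largely on its own. No step beyond the scatter is therefore expected for compound 4, with an estimated no change at the digits printed from compound 1 to compound 4 (within the scatter). Compound 4 is expected to give 89%, between 80% and 97%.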

Compound 4, largest response reached (Emax), in percent of the reference or control that the assay uses: 97%
For compound 4 the middle estimate is 8 percentage points below the measured one; the measured number falls inside the stated range.
By their numbers in this assay, from the lowest: compounds 2, 1, 3 and 4 (each within the scatter of the next).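

Extending the methyl to ethyl on this aromatic carbon gives, in this assay, a number 8 percentage points higher from compound 1 to compound 4 (within the scatter) and so adds no step beyond the scatter. Ethyl in place of acetyl at the same place gives a number 9 percentage points higher from compound 2 to compound 4 (within the scatter) and likewise stays inside it, so methyl, ethyl and acetyl are all accommodated here without a clear change in maximal response. Nothing available explains this result. Still open, as far as these compounds go, is whether a longer chain, an amine or a carboxylic acid at this place would keep the response.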